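A few compounds are considered here, and "the series" means these few. Any claim that something is new, unique, unknown or untested is made for them only; others in the source may bear on it.

Compound 1 `C[C@@H](NC(=O)c1ccc(C#Cc2ccc(F)cc2)cn1)C(C)(C)O` gives 66.2% in a functional assay on HEK293 cells for positive allosteric modulation of metabotropic glutamate receptor 5 (Rattus norvegicus), read by fluorescence and calcium flux; a higher number here means a larger maximal response, a lower number a smaller maximal response.
Compound 2 `C[C@@H](NC(=O)c1ccc(C#Cc2cccc(F)c2)nn1)C(C)(C)O` gives 70.2%.
Compound 3 `C[C@@H](NC(=O)c1ccc(C#Cc2cccc(F)c2)cn1)C(C)(C)C` gives 66%.

Compound 3 holds the lowest of the three numbers, yet its distance to compound 1 and to compound 2 lies within the usual scatter, so the three compounds cannot be placed in any order. Compound 4 `CC1(CNC(=O)c2ccc(C#Cc3cccc(F)c3)cn2)COC1` has not been measured. It differs from compound 3 in one place: (3-methyloxetan-3-yl)methyl in place of 1,2,2-trimethylpropyl on an amide-type nitrogen. Among the compounds with values here, no pair of measured compounds shows a change of this kind, so nothing here tells how far such a step can reach. The three measured values sit close together, and the step of a number 1 percentage points lower from compound 3 to compound 4 (within the scatter) is expected to stay within the scatter. For compound 4 the expected value is 65%, in a range from 50% to 80%.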

Compound 4, largest response reached (reported as efficacy), in percent of the reference or control that the assay uses: 60.4%
For compound 4 the middle estimate is 4.6 percentage points above the measured one, within the range that was stated.
By their numbers in this assay, from the lowest: compounds 4, 3, 1 and 2 (each within the scatter of the next).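

In this assay, placing (3-methyloxetan-3-yl)methyl instead of 1,2,2-trimethylpropyl on the amide-type nitrogen gives a step within the scatter (a number 5.6 percentage points lower from compound 3 to compound 4 (within the scatter)). At this place, then, the maximal response tolerates a four-membered ring containing oxygen, a hydrogen-bond acceptor and the loss of the defined stereocentre. Nothing shown explains this outcome. On these data alone, whether a group carrying an amine or a carboxylic acid would be tolerated at this place remains open, as does whether the same change would behave alike on the core of compound 2.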